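Dropping the ethyl group from compound 3

A few compounds are considered here, and "the series" means these few. Any claim that something is new, unique, unknown or untested is made for them only; others in the source may bear on it.

Measured compounds:
compound 1, `O=C(Nc1cc(C(F)(F)F)cc(C(F)(F)F)c1)c1cnc(Cl)nc1C(F)(F)C(F)(F)F`, 800 nM
compound 2, `O=C(Nc1cc(C(F)(F)F)cc(C(F)(F)F)c1)c1cnc(C(F)(F)F)nc1Cl`, > 10000 nM
compound 3, `CCc1nc(Cl)ncc1C(=O)Nc1cc(C(F)(F)F)cc(C(F)(F)F)c1`, 400 nM

Of the compounds shown here, three sharing one amide core have been measured in an assay on Jurkat cells for activation of nuclear factor NF-kappa-B complex (Homo sapiens); a higher number here means a weaker inhibitor, a lower number a stronger inhibitor. Compound 3 gives 400 nM, the lowest of the two numbers obtained; the nearest is compound 1 with 800 nM, and the gap between them, a 2.0-fold lower number from compound 1 to compound 3 (0.30 log units; within the scatter), lies within the scatter. Compound 2 returns only a limit, > 10000 nM, so no number is known for it.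

The next compound, compound 4, `O=C(Nc1cc(C(F)(F)F)cc(C(F)(F)F)c1)c1cnc(Cl)nc1`, differs from compound 3 by hydrogen in place of ethyl on an aromatic carbon. For the measured compounds named here, only one measured step touches this part of the shared core: the exchange of pentafluoroethyl for ethyl, from compound 1 to compound 3, which gave a 2.0-fold lower number from compound 1 to compound 3 (0.30 log units; within the scatter), a change within the scatter. Going by the values given here, that step swaps one group for another of similar size; removing the group altogether has no measured counterpart here, so the outcome is open. On that basis the number for compound 4 in this assay is expected to stay near the value of compound 3 or to rise somewhat, an expected step of a 3.0-fold higher number from compound 3 to compound 4 (0.48 log units; beyond the scatter).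

For compound 4 the estimate is 1200 nM, with a range from 300 nM to 5000 nM.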

Compound 4, half-maximal inhibitory concentration: 300 nM
Compound 4: the middle estimate sits 4.0-fold (0.60 log units) above what was measured, and the stated range covers the measured number.
By their numbers in this assay, from the lowest: compounds 4, 3 and 1 (each within the scatter of the next, the first and the last beyond it). At a limit, above all of these: compound 2.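

In this assay, the aromatic carbon next to the ring nitrogen and ortho to a large group turns out to need no substituent for the number to hold: hydrogen in place of ethyl gives a 1.3-fold lower number from compound 3 to compound 4 (0.12 log units; within the scatter) and so leaves compound 3 and compound 4 indistinguishable. Hydrogen in place of 1,1,2,2,2-pentafluoroethyl gives a 2.7-fold lower number from compound 1 to compound 4 (0.43 log units; beyond the scatter) and is the first step at this position to pass beyond the scatter, though only modestly. Ethyl lies within the scatter of both of the other groups, so across compound 1, compound 3 and compound 4 only the two ends of the series can be told apart, and the position tolerates all three groups with little separation between them.

Nothing shown here accounts for the size of these steps and the reason for this tolerance stays unknown. As far as these compounds go, it also remains open whether an amine, a methoxy group or a chain longer than ethyl on this aromatic carbon would keep the number in the same range or move it clearly away.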